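Chain extension at the aryl ether oxygen: compound 4

This account rests on a few compounds, and the source may have more. Where it says the series, first, only, none or still open, it means among the compounds named here.

compound 1 `COC[C@@H](C1CC1)n1cc(Cl)nc(Nc2cc(C)c(OCF)cc2C)c1=O` — 4.1 nM
compound 2 `COC[C@@H](C1CC1)n1cc(Cl)nc(Nc2cc(C)c(OCCF)cc2C)c1=O` — 2.4 nM
compound 3 `COCC(COC)n1cc(Cl)nc(Nc2c(Cl)cc(OC)cc2Cl)c1=O` — 5 nM

In an assay on frontal cortex for displacement of a labelled ligand from corticotropin-releasing factor receptor 1 (Rattus norvegicus), with a stated time of 2 h (a lower number here means a stronger inhibitor, a higher number a weaker inhibitor), compound 3 gives the highest of the three numbers; the gap to compound 1 lies within the scatter, the gap to compound 2 beyond it. Compound 4 `COCC(COC)n1cc(Cl)nc(Nc2c(Cl)cc(OCCF)cc2Cl)c1=O` differs from compound 3 by fluoromethyl in place of hydrogen on a saturated chain carbon bound to an oxygen on an aromatic ring. Among the compounds with values here, no measured pair shows this exact change; the closest is a 1.7-fold lower number from compound 1 to compound 2 (0.23 log units; within the scatter), a change at the same saturated chain carbon bound to an oxygen on an aromatic ring that stayed within the scatter. On that basis compound 4 is expected to move little in this assay, a 1.4-fold lower number from compound 3 to compound 4 (0.15 log units; within the scatter), if anything toward a lower number. The estimate for compound 4 is 3.5 nM, with a range from 1.5 nM to 9 nM.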

Compound 4, half-maximal inhibitory concentration in the corticotropin-releasing factor receptor 1 assay: 210 nM
Compound 4: the middle estimate sits 60-fold (1.78 log units) below what was measured, outside the stated range (above it).
By their numbers in the corticotropin-releasing factor receptor 1 assay, from the lowest: compounds 2, 1 and 3 (each within the scatter of the next, the first and the last beyond it); then compound 4.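

In the corticotropin-releasing factor receptor 1 assay, fluoromethyl in place of hydrogen on a saturated chain carbon bound to an oxygen on an aromatic ring is far from neutral on the core of compound 3: compound 3 gives 5 nM and compound 4 gives 210 nM, which is a 42-fold higher number from compound 3 to compound 4 (1.62 log units; beyond the scatter); the tolerance of a 1.7-fold lower number from compound 1 to compound 2 (0.23 log units; within the scatter) does not carry over to this core. In a physicochemical assay for lipophilicity, using the shake flask method, in phosphate buffer, measured as octanol-water partition, at pH 7.4 (on this read-out higher numbers stand for higher lipophilicity and lower numbers for lower lipophilicity), compound 3 gives 3.4 and compound 4 gives 3.1, so the same change gives a number 0.30 log units lower from compound 3 to compound 4 (within the scatter). No measurement at hand accounts for the loss.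

On these data alone, whether the loss follows the fluorine or the chain alone stays open. An ethoxy or a longer unfluorinated chain on the core of compound 3 would separate the two.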